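The compounds below may be only part of what the source reports. "The series", "measured", "known", "first", "only" and "open" are said of these compounds alone.

Compound 2 `CCCCOC(=O)Nc1ccc([Se]C#N)cc1` was measured in a functional assay on CCRF-CEM cells (Homo sapiens) for cytotoxicity, read by MTT assay, with a stated time of 72 h (a lower number here means a stronger inhibitor of growth, a higher number a weaker inhibitor of growth), and gives 27900 nM. Two related compounds were measured alongside it. Compound 1 `CCCOC(=O)Nc1ccc([Se]C#N)cc1`, which carries a shorter chain on the carbamate, gives 38400 nM, and compound 3 `CCOC(=O)Nc1ccc([Se][Se]c2ccc(NC(=O)OCC)cc2)cc1`, in which two aryl units are joined through a diselenide instead of carrying a selenocyanate, gives 49500 nM. The only single-point step among these, a 1.4-fold lower number from compound 1 to compound 2 (0.14 log units; within the scatter), shows that adding one carbon to the chain did not move the number beyond the usual scatter. Compound 2 holds the lowest of the three numbers, yet both other values sit within the scatter of it, so the three compounds cannot be told apart on these data.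

Compound 4 `CC(C)COC(=O)Nc1ccc([Se]C#N)cc1` is the next compound to be tested. It differs from compound 2 in one respect: isopropyl in place of propyl on a saturated chain carbon bound to an oxygen next to a carbonyl group. The same atoms are present, only joined differently. Within the data shown here, no measured step bears on branching of this chain; the nearest comparison, a 1.4-fold lower number from compound 1 to compound 2 (0.14 log units; within the scatter), concerns chain length and lay within the scatter. The step from compound 2 to compound 4 is therefore expected to be none beyond the scatter, a 1.0-fold higher number from compound 2 to compound 4 (0.00 log units; within the scatter). Compound 4 is estimated to give 28000 nM, with a likely range from 14000 nM to 56000 nM.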

Compound 4, concentration for total growth inhibition: 38300 nM
Estimate against measurement, compound 4: 1.4-fold (0.14 log units) below, within the range that was stated.
By their numbers in this assay, from the lowest: compounds 2, 4, 1 and 3 (each within the scatter of the next).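

Branching now has a reading of its own, where the earlier compounds spoke only to chain length: in this assay, rearranging the butyl chain into an isobutyl chain, with isopropyl in place of propyl on a saturated chain carbon bound to an oxygen next to a carbonyl group, gives a 1.4-fold higher number from compound 2 to compound 4 (0.14 log units; within the scatter). Seen from the shorter chain, methyl in place of hydrogen on a saturated chain carbon bound to two saturated chain carbons gives a 1.0-fold lower number from compound 1 to compound 4 (0.00 log units; within the scatter), so neither route to the branched chain moves the number beyond the scatter, and these carbamate chains, whether lengthened or branched, cannot yet be told apart. No measurement shown here offers an explanation for these small differences.

Going by these compounds, what a much longer chain, a phenyl ring or an amine at the end of the chain would do at this position remains open, as every step seen so far lies within the scatter. Also open, on these data alone, is whether an isobutyl chain would behave alike on a compound carrying a diselenide in place of the selenocyanate.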